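Compound 3: cyano in place of bromo

This account rests on a few compounds, and the source may have more. Where it says the series, first, only, none or still open, it means among the compounds named here.

Of the compounds shown here, three sharing one core have been tested in a functional assay on SMMC-7721 cells (Homo sapiens) for cytotoxicity, read by MTT assay, with a stated time of 24 h; on this read-out higher numbers stand for weaker inhibition and lower numbers for stronger inhibition. Compound 1 `O=C1/C(=C/c2cccnc2)CN(S(=O)(=O)c2ccccc2)C/C1=C\c1ccccc1C(F)(F)F` gives 10900 nM, compound 2 `O=C1/C(=C/c2cccnc2)CN(S(=O)(=O)c2ccc(C(F)(F)F)cc2)C/C1=C\c1ccccc1C(F)(F)F` gives 1730 nM, and compound 3 `O=C1/C(=C/c2cccnc2)CN(S(=O)(=O)c2ccc(Br)cc2)C/C1=C\c1ccccc1C(F)(F)F` gives 5760 nM. Two steps fix where compound 3 stands: a 1.9-fold lower number from compound 1 to compound 3 (0.28 log units; within the scatter), and a 3.3-fold higher number from compound 2 to compound 3 (0.52 log units; beyond the scatter). Its number thus cannot be told apart from that of compound 1, while that of compound 2 is clearly lower.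

Compound 4 `N#Cc1ccc(S(=O)(=O)N2C/C(=C\c3cccnc3)C(=O)/C(=C/c3ccccc3C(F)(F)F)C2)cc1` differs from compound 3 in one group, with cyano in place of bromo on an aromatic carbon, para to a large group (cyano in place of bromo on an aromatic carbon). Among the compounds with values here, no cyano compound has been measured in this assay, so no step speaks to this change directly. The closest guides are the other exchanges at the same place, a 6.3-fold lower number from compound 1 to compound 2 (0.80 log units; beyond the scatter), and the step from compound 2 to compound 3 already given, both modest. A step of modest size at most therefore seems likely, and the lean towards a lower number rests only on compound 2 at 1730 nM. The expected change is a 1.6-fold lower number from compound 3 to compound 4 (0.22 log units; within the scatter). For compound 4 the estimated value is 3500 nM, with an expected range from 1300 nM to 9500 nM.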

Compound 4, half-maximal inhibitory concentration: 9650 nM
Compound 4: middle estimate off by 2.8-fold (0.44 log units), on the low side, and the stated range ends below it.
By their numbers in this assay, from the lowest: compound 2; then compounds 3, 4 and 1 (each within the scatter of the next).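

In this assay, the exchange of bromo for cyano on an aromatic carbon, para to a large group, gives a 1.7-fold higher number from compound 3 to compound 4 (0.22 log units; within the scatter) and so separates the two groups no more than the scatter allows, while a 1.1-fold lower number from compound 1 to compound 4 (0.05 log units; within the scatter) shows that cyano cannot be told apart from the plain hydrogen of compound 1 either. Compound 2 now stands alone, with a 5.6-fold higher number from compound 2 to compound 4 (0.75 log units; beyond the scatter) adding to its earlier step from compound 1, so that among hydrogen, bromo, cyano and trifluoromethyl at this place only trifluoromethyl gives a number clearly set apart from hydrogen. Nothing shown here accounts for trifluoromethyl behaving differently from cyano and bromo.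

On these data alone, whether the lower number of compound 2 is particular to trifluoromethyl remains open, since the series holds no methoxy, amine, carboxylic acid or longer alkyl chain at this place to test it. As far as these compounds go, all four compounds also share the same remainder of the core, so it stays unknown whether the same order of groups would hold if that remainder were changed.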